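This account rests on a few compounds, and the source may have more. Where it says the series, first, only, none or still open, it means among the compounds named here.

Working notes on the series.

Compound 1 `O=[N+]([O-])c1ccc(-c2nc3cc(C(F)(F)F)ccc3[nH]2)c([N+](=O)[O-])c1` is the reference point here. In an ADME assay on Vero cells (Chlorocebus sabaeus) for cytotoxicity (a lower number here means that less compound is tolerated, a higher number that more compound is tolerated), compound 1 gives 25000 nM. Compound 3 `CC(=O)Nc1ccc(-c2nc3cc(C(F)(F)F)ccc3[nH]2)cc1` shares a core with it, but how the two cores differ is not broken down here; in this assay compound 3 gives 50000 nM. Compound 2 `CC(=O)Nc1ccc(-c2nc3ccccc3[nH]2)cc1` carries the core of compound 3 without its trifluoromethyl. In this assay compound 2 reaches only a limit of the assay, > 100000 nM, not a number; this is the limit of > 100000 nM in this assay, at which 1 of the 3 values shown sits.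

The measured step from compound 3 to compound 2 is an at least 2.0-fold higher number from compound 3 to compound 2 (0.30 log units; that floor lies within the scatter), the change being (hydrogen in place of trifluoromethyl on an aromatic carbon).

Compound 4 `O=[N+]([O-])c1ccc(-c2nc3ccccc3[nH]2)c([N+](=O)[O-])c1` is not yet measured. It differs from compound 1 by hydrogen in place of trifluoromethyl on an aromatic carbon. The place described for this change is word for word the same as for the change from compound 3 to compound 2, so this is the same change, made a second time on a different core.

What to expect: the step from compound 1 to compound 4 in this assay is estimated at a 2.0-fold higher number from compound 1 to compound 4 (0.30 log units; within the scatter), and this rests on the earlier step of an at least 2.0-fold higher number from compound 3 to compound 2 (0.30 log units; that floor lies within the scatter), with the caution that the earlier step is known only as a floor that lies within the scatter because of the limit of > 100000 nM in this assay, at which 1 of the 3 values shown sits. On this basis compound 4 is expected to give about 50000 nM in this assay, with a plausible range from 20000 nM to 125000 nM.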

Compound 4, half-maximal cytotoxic concentration: > 100000 nM
Compound 4 was reported as a limit (the forecaster's own chance of this, stated with the estimate: 25%); middle value at least 2.0-fold (0.30 log units) away from the limit.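

In this assay compound 4 gives > 100000 nM, which is a limit of the assay and not a number. Hydrogen in place of trifluoromethyl on an aromatic carbon therefore reads as an at least 4.0-fold higher number from compound 1 to compound 4 (0.60 log units; beyond the scatter) on the core of compound 1, and set beside the same change on the other core it gives this picture: the same change on two cores in this assay, an at least 2.0-fold higher number (0.30 log units; that floor lies within the scatter) from compound 3 to compound 2 and an at least 4.0-fold higher number (0.60 log units; beyond the scatter) from compound 1 to compound 4; the limit leaves it open whether they differ. The two steps agree in that neither shows a lower number after trifluoromethyl leaves, but they give no true size for the change on either core, and whether it carries over with the same size stays unsettled because of the shared ceiling: the limit of > 100000 nM in this assay, at which 2 of the 4 values shown sit.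

The compounds shown leave open how other groups at this place, such as a chlorine atom, a methoxy group or a nitrile, would read in this assay, as only trifluoromethyl and hydrogen are compared here. They also leave open whether the change behaves alike on a core carrying an amine or a carboxylic acid, as the comparison so far rests on just two cores.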